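Replacing a pyridyl ring by chlorophenyl on the shared core

The source may hold more compounds than are shown below. What is called first, only, known or untested is meant among the compounds shown, and "the series" means these compounds.

The series shares the core shown in compound 1 `Cc1nn(-c2nc(-c3ccc(Cl)c(Cl)c3)c(SC(C)C)s2)c(C(=O)O)c1-c1cncc(C#N)c1` and compound 2 `Cc1nn(-c2nc(-c3ccc(Cl)c(Cl)c3)c(SC(C)C)s2)c(C(=O)O)c1-c1cccnc1`. In a functional assay on BJAB cells (Homo sapiens) for antiproliferative activity, with a stated time of 4 days (on this read-out higher numbers stand for an effect only at larger amounts of compound and lower numbers for an effect already at smaller amounts), compound 1 gives 20000 nM, and compound 2 gives 12000 nM. For the measured compounds named here, the only step between measured compounds, a 1.7-fold lower number from compound 1 to compound 2 (0.22 log units; within the scatter), is too small to carry meaning, so compound 2 stands on the lowest of the two numbers without being separated from compound 1 beyond the scatter.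

Compound 3 `Cc1nn(-c2nc(-c3ccc(Cl)c(Cl)c3)c(SC(C)C)s2)c(C(=O)O)c1-c1cccc(Cl)c1` has not been measured in this assay. It differs from compound 2 by 3-chlorophenyl in place of pyridin-3-yl on an aromatic carbon. Going by the values given here, no measured step alters this ring itself; the single known step only removed a cyano group from it and stayed within the scatter. There is therefore no measured evidence that exchanging the ring for 3-chlorophenyl moves the number in either direction, and the expectation is a step of about a 1.2-fold lower number from compound 2 to compound 3 (0.08 log units; within the scatter), which is no change beyond the scatter. On that basis compound 3 is estimated at 10000 nM in this assay, with a range from 3000 nM to 30000 nM.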

Compound 3, half-maximal effective concentration: 13600 nM
Compound 3: the middle estimate sits 1.4-fold (0.13 log units) below what was measured, and the stated range covers the measured number.
By their numbers in this assay, from the lowest: compounds 2, 3 and 1 (each within the scatter of the next).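

In this assay, the exchange of pyridin-3-yl for 3-chlorophenyl on this aromatic carbon gives a 1.1-fold higher number from compound 2 to compound 3 (0.05 log units; within the scatter), and the exchange of 5-cyanopyridin-3-yl for 3-chlorophenyl gives a 1.5-fold lower number from compound 1 to compound 3 (0.17 log units; within the scatter). The earlier step altered only a substituent on the pyridine ring, whereas these two replace the whole ring, taking away its ring nitrogen and putting a carbon-only ring carrying chlorine in its place, and the compounds still cannot be told apart. Here, then, neither the ring nitrogen nor the nitrile separates any of the three compounds, and nothing available explains why the numbers lie so close together.

On these data alone, all three compounds carry a six-membered aromatic ring at this position, so it remains open whether a saturated ring such as cyclohexyl or morpholine, or a simple amine, on this carbon would move the number beyond the scatter. As far as these compounds go, the carboxy group and the methyl group on the neighbouring ring atoms are also the same throughout, so whether this position behaves the same way with an amide in place of the carboxy group remains open too.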